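Trifluoromethyl in place of fluoro: compound 3 to compound 4

The compounds below may be only part of what the source reports. "The series", "measured", "known", "first", "only" and "open" are said of these compounds alone.

In a functional assay on MOLT-4 cells (Homo sapiens) for inhibition, read by MTT assay, with a stated time of 72 h (on this read-out lower numbers stand for stronger inhibition and higher numbers for weaker inhibition), compound 3 `COc1cc(NC(C)CCCNC(=O)NNC(=O)Nc2cccc(F)c2)c2ncccc2c1` gives >= 250000 nM, which is a limit and not a number. Compound 1 `COc1cc(NC(C)CCCNC(=O)NNC(=O)Nc2ccc(F)cc2)c2ncccc2c1` gives >= 250000 nM, also a limit. Compound 2 `COc1cc(NC(C)CCCNC(=O)NNC(=O)Nc2ccc(C(F)(F)F)cc2)c2ncccc2c1` is the only one of the three with a number, 24000 nM.

Compound 4 `COc1cc(NC(C)CCCNC(=O)NNC(=O)Nc2cccc(C(F)(F)F)c2)c2ncccc2c1` differs from compound 3 by one exchange trifluoromethyl in place of fluoro on an aromatic carbon, meta to a large group.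

Among the measured compounds shown here, the closest precedent is the same exchange made elsewhere on the ring, which gave an at least 10-fold lower number from compound 1 to compound 2 (1.01 log units; beyond the scatter). For the measured compounds named here, this large step is the only direct evidence, and it comes from a single pair. The step of an at least 10-fold higher number from compound 2 to compound 3 (1.01 log units; beyond the scatter) changes the group and its place together, so it mirrors that precedent without isolating the exchange. The step that the two limits leave unreadable from compound 1 to compound 3 is left unreadable by its two limits, so the data give no measured effect of place alone.

A large step towards a lower number is therefore expected, though a result again at a limit remains possible. The expected change is an at least 6.2-fold lower number from compound 3 to compound 4 (0.79 log units; beyond the scatter). For compound 4 the estimate is 40000 nM, with an expected range of 12000 nM to 200000 nM.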

Compound 4, half-maximal inhibitory concentration: 36000 nM
Compound 4: the middle estimate sits 1.1-fold (0.05 log units) above what was measured, and the stated range covers the measured number.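

In this assay, trifluoromethyl in place of fluoro also lowers the number at this position, which gives an at least 6.9-fold lower number from compound 3 to compound 4 (0.84 log units; beyond the scatter), so the change no longer rests on a single pair: the same change on two cores in this assay, an at least 10-fold lower number (1.01 log units; beyond the scatter) from compound 1 to compound 2 and an at least 6.9-fold lower number (0.84 log units; beyond the scatter) from compound 3 to compound 4; the limit leaves it open whether they differ

With trifluoromethyl on the ring, 3-(trifluoromethyl)phenyl and 4-(trifluoromethyl)phenyl are not separated, as a 1.5-fold higher number from compound 2 to compound 4 (0.18 log units; within the scatter) lies within the scatter, so among the compounds shown the identity of the group counts for more than its place. Among the compounds shown here, the step that changes both group and place, an at least 6.9-fold lower number from compound 1 to compound 4 (0.84 log units; beyond the scatter), fits this reading, as both trifluoromethyl compounds give numbers and both fluoro compounds sit at a limit, with no compound of the four going against it.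

The step between the two fluoro compounds cannot be read, so whether place matters with fluoro stays open: the limit of >= 250000 nM in this assay, at which 2 of the 4 values shown sit.

Also open, on these data alone, is whether a chloro, methoxy or nitrile group in place of trifluoromethyl on this ring would give a number like those of the trifluoromethyl compounds or stay at the limit.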